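The source may report more compounds than this note shows. Statements on the series, on what has been measured and on what is new or still open speak of the compounds shown alone.

Measured so far:

compound 1, `Cc1cccc(C(=O)OC(CCN(C)C)c2ccc(Cl)cc2)c1C`: in an assay on NIH3T3 cells with Urotensin-2 receptor (Homo sapiens) as the target (on this read-out higher numbers stand for an effect only at larger amounts of compound and lower numbers for an effect already at smaller amounts), compound 1 gives 1150 nM
compound 2, `COc1cccc(C(=O)OC(CCN(C)C)c2ccc(Cl)cc2)c1C`: in this assay compound 2 gives 1950 nM
compound 3, `Cc1cccc(C(=O)NC(CCN(C)C)c2ccc(Cl)cc2)c1C`: in this assay compound 3 gives 3630 nM

Compound 1 and compound 2 share a core and differ in one place: methoxy in place of methyl on an aromatic carbon. In this assay this change made a 1.7-fold higher number from compound 1 to compound 2 (0.23 log units; within the scatter), so the two numbers cannot be told apart with confidence.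

Compound 3 carries a different core; the difference between the two cores is not broken down here. Its number in this assay lies within the scatter of the number of compound 2, while against compound 1 it stands beyond the scatter.

Compound 4, `COc1cccc(C(=O)NC(CCN(C)C)c2ccc(Cl)cc2)c1C`, has not been measured. It stands to compound 3 as compound 2 stands to compound 1: methoxy in place of methyl on an aromatic carbon. The surroundings of the place are described in the same words in both pairs, so this is the same change, made on the other core. Going by the values given here, the only guide is the step from compound 1 to compound 2, which stayed within the scatter. With nothing pointing the other way, compound 4 is expected to behave much like compound 3, perhaps with a slightly higher number in this assay because of a 1.7-fold higher number from compound 1 to compound 2 (0.23 log units; within the scatter). The estimated step is a 1.7-fold higher number from compound 3 to compound 4 (0.22 log units; within the scatter). Compound 4 is thus expected to give about 6000 nM in this assay, most likely between 2500 nM and 14000 nM.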

Compound 4, half-maximal effective concentration: 4270 nM
For compound 4 the middle estimate is 1.4-fold (0.15 log units) above the measured one, and the stated range covers the measured number.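

In this assay, putting methoxy in place of methyl on the aromatic carbon of the core of compound 3 gave a 1.2-fold higher number from compound 3 to compound 4 (0.07 log units; within the scatter), so on this core too the two numbers cannot be told apart with confidence. The change therefore carried over from one core to the other without any detectable difference, and the two steps agree as closely as measurements of this kind can show: the same change on two cores in this assay, a 1.7-fold higher number (0.23 log units; within the scatter) from compound 1 to compound 2 and a 1.2-fold higher number (0.07 log units; within the scatter) from compound 3 to compound 4, 1.4-fold (0.16 log units) apart, within the scatter of two such steps. This does not prove that the change has no effect or that the two cores respond identically, since a small real difference could be hidden in the scatter, and two pairs of compounds say nothing about other cores or about why the steps look alike.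

The compounds shown leave open what other groups at this same place would do, such as a hydrogen, a chlorine atom, a hydroxyl or an ethoxy group, and whether any of them would move the number beyond the scatter. They also leave open whether the same agreement between the two cores would hold with a longer chain or with a pyrrolidine ring in place of the dimethylamino group.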